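Replacing the acid-bearing cyclopentyl with a carboxypropoxy chain

This account rests on a few compounds, and the source may have more. Where it says the series, first, only, none or still open, it means among the compounds named here.

Compound 1 `c1ccc2nc(COc3ccc(OCCCc4nnn[nH]4)cc3)ccc2c1`: in an assay on membranes from lung (Cavia porcellus) for binding affinity to cysteinyl leukotriene receptor (Homo sapiens) (on this read-out higher numbers stand for weaker inhibition and lower numbers for stronger inhibition), compound 1 gives 69 nM.
Compound 2 `O=C(O)CC1CCC(c2ccc(OCc3ccc4ccccc4n3)cc2)C1`: in this assay compound 2 gives 22 nM.

Compound 2 stands at the lowest of the two numbers; its nearest neighbour is compound 1, and the change between them is a 3.1-fold lower number from compound 1 to compound 2 (0.50 log units; beyond the scatter). Compound 3 `O=C(O)CCCOc1ccc(OCc2ccc3ccccc3n2)cc1` differs from compound 2 by 3-carboxypropoxy in place of 3-(carboxymethyl)cyclopentyl on an aromatic carbon. Among the measured compounds shown here, the only measured step that bears on this, from compound 1 to compound 2, shows that swapping one acidic side chain for the other moves the number by a modest amount beyond the scatter. Compound 3 carries an open chain ending in a carboxylic acid, resembling compound 1 more than compound 2. Compound 3 is therefore expected to move back toward the number of compound 1, by a 2.7-fold higher number from compound 2 to compound 3 (0.44 log units; beyond the scatter), and its estimated value is 60 nM with a range from 20 nM to 200 nM.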

Compound 3, inhibition constant: 1200 nM
For compound 3 the middle estimate is 20-fold (1.30 log units) below the measured one, and the stated range ends below it.
By their numbers in this assay, from the lowest: compound 2; then compound 1; then compound 3.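

In this assay, the 3-carboxypropoxy chain on this aromatic carbon, para to a large group, is no match for the 3-(carboxymethyl)cyclopentyl it replaces: the change gives a 55-fold higher number from compound 2 to compound 3 (1.74 log units; beyond the scatter), a large step that the earlier pair gave no hint of. The end of the open chain counts as well, since carboxy in place of 1H-tetrazol-5-yl gives a 17-fold higher number from compound 1 to compound 3 (1.24 log units; beyond the scatter), so having an open chain does not by itself set the number. Nothing measured here accounts for either step.

As far as these compounds go, it remains open whether a 1H-tetrazol-5-yl group in place of the carboxy on the cyclopentyl side chain would keep the number of compound 2. From the compounds shown here alone, whether a longer chain ending in a carboxylic acid would undo the loss seen with compound 3 also remains open.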